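The compounds below may be only part of what the source reports. "The series", "measured", "known", "first", "only" and "open" are said of these compounds alone.

Working notes on the series.

Compound 1 `COc1ccc(/C=C/C(=O)c2sc(Nc3ccc(Cl)cc3)nc2C)cc1` is the reference point. In a functional assay on BGC-823 cells (Homo sapiens) for cytotoxicity, read by MTT assay (a higher number here means a weaker inhibitor, a lower number a stronger inhibitor), compound 1 gives only a limit, > 25000 nM, and no number. Compound 2 `COc1cccc(/C=C/C(=O)c2sc(Nc3ccc(Cl)cc3)nc2C)c1` carries a 3-methoxyphenyl in place of the 4-methoxyphenyl. In this assay compound 2 likewise gives only a limit, > 25000 nM. Compound 3 `Cc1nc(Nc2ccc(Cl)cc2)sc1C(=O)/C=C/c1ccc(Cl)cc1` carries chloro in place of methoxy on the aromatic carbon. In this assay compound 3 also returns only a limit, > 25000 nM. Because of the limit of > 25000 nM in this assay, at which 3 of the 3 values shown sit, none of the steps between these three can be read: the step from compound 1 to compound 2 is a step that the two limits leave unreadable from compound 1 to compound 2, the step from compound 1 to compound 3 is a step that the two limits leave unreadable from compound 1 to compound 3, and the step from compound 2 to compound 3 is a step that the two limits leave unreadable from compound 2 to compound 3.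

Compound 4 `COc1ccc(/C=C/C(=O)c2sc(Nc3ccc(Cl)c(Cl)c3)nc2C)cc1` differs from compound 1 by chloro in place of hydrogen on an aromatic carbon, that is, on the anilino side rather than on the styryl side where the three measured changes sit. Among the measured compounds shown here, no measured step bears on this position, and no readable step exists at all. On the numbers shown, the whole series sits at the limit, and compound 4 is expected to do the same, with a step from compound 1 to compound 4 of a step that the limit leaves unreadable from compound 1 to compound 4 that is not beyond the scatter. The estimate for compound 4 in this assay is 30000 nM, between 8000 nM and 80000 nM.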

Compound 4, half-maximal inhibitory concentration: > 25000 nM
Compound 4: no number, only a limit; the forecaster's own chance of this, stated with the estimate: 75%; the middle value does not contradict the limit.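

Compound 4 also returns only a limit, > 25000 nM, so the new step from compound 1 to compound 4 cannot be read, and the series gains no size of change: the limit of > 25000 nM in this assay, at which 4 of the 4 values shown sit.

The compounds shown leave open how large the effect of any of these changes is in this assay, and whether any change to the core of compound 1 yields a number there.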